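Sulfur for oxygen at the aryl linker, compound 4

This account rests on a few compounds, and the source may have more. Where it says the series, first, only, none or still open, it means among the compounds named here.

Compound 1 `COc1ccc(Sc2nc3cc(N)cc(N)c3nc2-c2ccccc2)cc1` gives in a functional assay on UO-31 cells (Homo sapiens) for inhibition, read by sulforhodamine B assay, with a stated time of 48 h (on this read-out lower numbers stand for stronger inhibition of growth and higher numbers for weaker inhibition of growth), only a limit of the assay, < 100000 nM.
Compound 2 `Nc1cc(N)c2nc(-c3ccccc3)c(Sc3ccc(Cl)c(Cl)c3)nc2c1` gives in this assay only a limit of the assay, < 100000 nM.
Compound 3 `Nc1cc(N)c2nc(-c3ccccc3)c(Oc3ccc(F)cc3)nc2c1` gives in this assay 45700 nM.

Among the measured compounds shown here, compound 3 stands as the only number in the set; the other two entries are limits. Compound 4 `Nc1cc(N)c2nc(-c3ccccc3)c(Sc3ccc(F)cc3)nc2c1` differs from it by (4-fluorophenyl)sulfanyl in place of 4-fluorophenoxy on an aromatic carbon. For the measured compounds named here, two measured steps touch a sulfur-for-oxygen exchange of this kind, a step that the limit leaves unreadable from compound 1 to compound 3 and a step that the limit leaves unreadable from compound 2 to compound 3, and both remain without readable size because the limit of < 100000 nM in this assay, at which 2 of the 3 values shown sit, hides the starting values. The third step, a step that the two limits leave unreadable from compound 1 to compound 2, runs between two sulfur-linked compounds and is likewise unreadable. Going by the values given here, no measured step therefore gives a direction or size for the change in this assay. The estimate for compound 4 is set at the value of compound 3, with a wide range and a real chance that the assay again returns only a limit. Compound 4 is expected at 45700 nM, between 15000 nM and 120000 nM. The expected step of no change at the digits printed from compound 3 to compound 4 (within the scatter) is none beyond the scatter.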

Compound 4, concentration for total growth inhibition: < 100000 nM
Compound 4 was reported as a limit; the forecaster's own chance of this, stated with the estimate: 40%; the middle value is on the limit's open side.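

Compound 4 gives only a limit of the assay, so no step linking it to compound 1, compound 2 or compound 3 can be read in this assay, because of this: the limit of < 100000 nM in this assay, at which 3 of the 4 values shown sit.
As far as these compounds go, whether sulfur in place of oxygen, or any change on the aryl ring, alters growth inhibition stays open in both direction and size.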